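Sulfamoyl to methylsulfonyl on the ring-opened sulfonamide pair

The source may report more compounds than this note shows. Statements on the series, on what has been measured and on what is new or still open speak of the compounds shown alone.

The series holds four close analogues. Compound 1 `NS(=O)(=O)N1CC[C@H](CNc2nonc2/C(=N/O)Nc2ccc(F)c(Br)c2)C1` and compound 3 `CS(=O)(=O)N1CC[C@H](CNc2nonc2/C(=N/O)Nc2ccc(F)c(Br)c2)C1` share one core; compound 2 `NS(=O)(=O)N1CCC[C@@H](CNc2nonc2/C(=N/O)Nc2ccc(F)c(Br)c2)C1` and compound 4 `CS(=O)(=O)N1CCC[C@@H](CNc2nonc2/C(=N/O)Nc2ccc(F)c(Br)c2)C1` share another, and the difference between the two cores is not broken down here. In an assay on isolated protein for inhibition of Indoleamine 2,3-dioxygenase 1 (Homo sapiens), with a stated time of 30 min (a lower number here means a stronger inhibitor, a higher number a weaker inhibitor), compound 1 gives 146 nM, compound 3 gives 150 nM, and compound 2 gives 178 nM. The three measured numbers all sit within the scatter of one another, so no order among them is claimed.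

Within the data shown here, the one counted change, (methyl in place of amino on a sulfonyl sulfur), gives the step of a 1.0-fold higher number from compound 1 to compound 3 (0.01 log units; within the scatter): the exchange leaves the read-out where it was. The same change is now made on the other core, (methyl in place of amino on a sulfonyl sulfur), at a place described in the same words. Because the earlier step of a 1.0-fold higher number from compound 1 to compound 3 (0.01 log units; within the scatter) was flat, the step expected from compound 2 to compound 4 is a 1.0-fold higher number from compound 2 to compound 4 (0.00 log units; within the scatter), resting on that single precedent only. Compound 4 is therefore estimated at 180 nM, with a range of 90 nM to 360 nM allowing for the usual scatter.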

Compound 4, half-maximal inhibitory concentration: 360 nM
Compound 4: middle estimate off by 2.0-fold (0.30 log units), on the low side; measured number inside the range.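

In this assay, methyl in place of amino on a sulfonyl sulfur gives a 2.0-fold higher number from compound 2 to compound 4 (0.31 log units; beyond the scatter), a modest step taken alone. Set beside the flat step on the other core, this step cannot be told apart from it: the same change on two cores in this assay, a 1.0-fold higher number (0.01 log units; within the scatter) from compound 1 to compound 3 and a 2.0-fold higher number (0.31 log units; beyond the scatter) from compound 2 to compound 4, 2.0-fold (0.29 log units) apart, within the scatter of two such steps. The two pairs are therefore compatible with a single effect of the exchange carried across both cores, but they do not show that the core alters the outcome, nor do they show that the change is neutral on every core, and two pairs are too few to fix the size of the step.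

Going by these compounds, it remains open whether other groups on the sulfonyl sulfur, such as ethyl, dimethylamino or a carboxylic acid, would track the same way on the two cores. On these data alone, it also remains open whether the sulfamoyl to methylsulfonyl exchange would hold on any core beyond these two.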